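The source may report more compounds than this note shows. Statements on the series, on what has been measured and on what is new or still open speak of the compounds shown alone.

Measured so far in an assay on isolated protein for inhibition of protoporphyrinogen oxidase (Homo sapiens), read by capillary electrophoresis; on this read-out lower numbers stand for stronger inhibition and higher numbers for weaker inhibition: compound 1 `CCOC(=O)CSc1nc2cc(-n3nc(C(C)(C)C)sc3=O)c(Cl)cc2s1` gives 5820 nM; compound 2 `CCOC(=O)CCSc1nc2cc(-n3nc(C(C)(C)C)sc3=O)c(Cl)cc2s1` gives 1280 nM; compound 3 `CCOC(=O)CCSc1nc2cc(-n3nc(C(C)(C)C)sc3=O)c(Br)cc2s1` gives 27500 nM.

The step from compound 1 to compound 2 is (ethoxycarbonyl)methyl in place of ethoxycarbonyl on a saturated chain carbon bound to a sulfur and brought a 4.5-fold lower number from compound 1 to compound 2 (0.66 log units; beyond the scatter). Compound 3 sits at the weak end, and the difference between its core and the core of compound 1 is not broken down here; from compound 2 it is reached by a 21-fold higher number from compound 2 to compound 3 (1.33 log units; beyond the scatter).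

Compound 4 `CCOC(=O)CCCSc1nc2cc(-n3nc(C(C)(C)C)sc3=O)c(Br)cc2s1` is not yet measured. It differs from compound 3 by (ethoxycarbonyl)methyl in place of ethoxycarbonyl on a saturated chain carbon, two bonds along the chain from a sulfur; this is the same kind of change as before, but the place differs, once bound to a sulfur and now two bonds along the chain from a sulfur. A modest step is expected for compound 4, a 3.4-fold lower number from compound 3 to compound 4 (0.54 log units; beyond the scatter), because the earlier change gave a 4.5-fold lower number from compound 1 to compound 2 (0.66 log units; beyond the scatter). Compound 4 is therefore estimated at 8000 nM, roughly between 2000 nM and 30000 nM.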

Compound 4, inhibition constant: 245000 nM
Estimate against measurement, compound 4: 31-fold (1.49 log units) below, and the stated range ends below it.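

In this assay, the same one-carbon lengthening of the ester chain now brought an 8.9-fold higher number from compound 3 to compound 4 (0.95 log units; beyond the scatter), so the change does not carry over from one core to another as a fixed gain, and its direction is reversed here: the same change on two cores in this assay, a 4.5-fold lower number (0.66 log units; beyond the scatter) from compound 1 to compound 2 and an 8.9-fold higher number (0.95 log units; beyond the scatter) from compound 3 to compound 4, 41-fold (1.61 log units) apart, beyond the scatter of two such steps

The two steps differ at once in the halogen on the core, chloro against bromo, and in the place on the chain. These four compounds cannot separate those two differences, so they do not show which one goes with the reversal.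

Open, on these data alone, is how the chloro core responds to the 3-(ethoxycarbonyl)propyl chain. Also open, as far as these compounds go, is whether a carboxylic acid in place of the ethyl ester would follow the same course.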